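The source may hold more compounds than are shown below. What is called first, only, known or untested is meant among the compounds shown, and "the series" means these compounds.

Measured so far in a functional assay on NCI-H460 cells (Homo sapiens) for inhibition, read by sulforhodamine B assay, with a stated time of 48 h; a higher number here means a weaker inhibitor of growth, a lower number a stronger inhibitor of growth:
compound 1 `CCOC(=O)C1=C(C)NC(=O)NC1c1ccc(O)c(O)c1` gives 34 ug/mL
compound 2 `CCCc1ccc(C2NC(=O)NC(C)=C2C(=O)OCC)cc1` gives 49.7 ug/mL

Compound 2 at 49.7 ug/mL stands within the scatter of compound 1, so the two numbers set no order between them.

Compound 3 `CCOC(=O)C1=C(C)NC(=O)NC1c1ccc(O)cc1` is still unmeasured. It carries hydroxy in place of propyl on an aromatic carbon of a six-membered aromatic ring of carbon only, para to a large group (hydroxy in place of propyl on an aromatic carbon). Among the measured compounds shown here, no two measured compounds differ in one place, so the series offers no direct step to guide this change.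

For the measured compounds named here, the only guide is the level of the two measured values. In this assay compound 1 at 34 ug/mL and compound 2 at 49.7 ug/mL lie close together, and no step beyond the scatter is expected here. With so little data, that expectation is weak and the range is kept wide. The estimated move (a 1.2-fold lower number from compound 2 to compound 3 (0.09 log units; within the scatter)) is small, slightly toward a lower number, and stays within the scatter. For compound 3 the estimated value is 40 ug/mL with an expected range from 15 ug/mL to 100 ug/mL in this read-out.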

Compound 3, concentration for 50% growth inhibition: 40.6 ug/mL
Compound 3: the middle estimate sits 1.0-fold (0.01 log units) below what was measured, within the range that was stated.
By their numbers in this assay, from the lowest: compounds 1, 3 and 2 (each within the scatter of the next).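

Two readable steps now exist in the series, and both concern the aromatic ring. In this assay, hydroxy in place of propyl on an aromatic carbon, para to a large group, gives a 1.2-fold lower number from compound 2 to compound 3 (0.09 log units; within the scatter), so a change from an alkyl chain to hydroxy at this position leaves the growth-inhibition number within the scatter. Hydrogen in place of hydroxy on an aromatic carbon gives a 1.2-fold higher number from compound 1 to compound 3 (0.08 log units; within the scatter), which is also within the scatter, so the second hydroxy of compound 1 has no readable effect in this read-out, and no measurement shown here speaks to the reason for either result.

The compounds shown leave open whether any group at the position para to the large group can move the number beyond the scatter, since the comparison there covers only propyl and hydroxy, and an amine, a carboxylic acid or a longer chain such as octyl would test a wider span of groups. Also open, from the compounds shown here alone, is how far the number depends on the ethyl ester of the shared core, as all three compounds carry it unchanged.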